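The compounds below may be only part of what the source reports. "The series", "measured", "known", "first", "only" and "open" are said of these compounds alone.

Measured compounds:
compound 1 `COc1ccccc1/C=c1/[nH]c(=O)/c(=C\c2ccccc2OC)n(C)c1=O` — "not active" (no number reported)
compound 2 `C=CCn1c(=O)/c(=C\c2ccccc2OC)[nH]c(=O)/c1=C\c1ccccc1OC` — 13400 nM

In a functional assay on BGC-823 cells (Homo sapiens) for cytotoxicity, read by CCK-8 assay, with a stated time of 72 h (on this read-out lower numbers stand for stronger inhibition and higher numbers for weaker inhibition), compound 2 gives 13400 nM. In this assay compound 1 is reported as "not active" (no number reported), with no number attached. Among the measured compounds shown here, compound 2 therefore carries the only number; compound 1 stands beside it without a value, so no step between the two measured compounds can be stated.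

Compound 3 `C=CCn1c(=O)/c(=C\c2cccc(C)c2)[nH]c(=O)/c1=C\c1ccccc1OC` is not yet measured. It differs from compound 2 in one place: 3-methylphenyl in place of 2-methoxyphenyl on a double-bonded chain carbon bound to an aromatic carbon. The shared core of compound 2 is kept, as is the second arylidene arm and the allyl group. For the measured compounds named here, no measured pair shows what this exchange does in this assay, so the expectation rests only on compound 2 and its value.

The step from compound 2 to compound 3 in this assay is expected to be small, within the usual scatter, with no direction claimed: a 1.1-fold higher number from compound 2 to compound 3 (0.05 log units; within the scatter). Compound 3 is estimated at 15000 nM in this assay, with a range from 5000 nM to 45000 nM; a report of no number, as for compound 1, remains possible.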

Compound 3, half-maximal inhibitory concentration: 20400 nM
The estimate for compound 3 lay 1.4-fold (0.13 log units) below the measured number; the range from low to high includes it.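

In this assay, among the compounds shown here, the exchange of 2-methoxyphenyl for 3-methylphenyl on a double-bonded chain carbon bound to an aromatic carbon gives a 1.5-fold higher number from compound 2 to compound 3 (0.18 log units; within the scatter) and is the first step that can be read. This place therefore accepts an aryl group with no hydrogen-bond acceptor in place of one with a single acceptor, with no separation between the two numbers beyond the scatter, so the methoxy oxygen of this arm is not shown to matter for the read-out in this one pair. Nothing measured here bears on the reason for this outcome.

Because the methoxy group and the methyl group also carry different numbers in their names, this single step cannot separate the identity of the group from where it stands on the aromatic ring, and it says nothing about the other arm, which stays 2-methoxyphenyl in both compounds. Still open, as far as these compounds go, is how this place responds to a group of a different kind, such as an amine or a carboxylic acid on the aromatic ring, and whether a longer chain in place of the allyl group changes the number.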